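The source may hold more compounds than are shown below. What is called first, only, known or untested is meant among the compounds shown, and "the series" means these compounds.

Compound 1, `O=C1c2c(ccc(O)c2O)CN1Cc1cccc(F)c1`, gives 8600 nM in an ADME assay on HOS cells (Homo sapiens) for cytotoxicity; a higher number here means a weaker inhibitor, a lower number a stronger inhibitor. Compound 2, `O=C1c2c(ccc(O)c2O)CN1Cc1cccc(Cl)c1`, gives 9020 nM in this assay, and compound 3, `O=C1c2c(ccc(O)c2O)CN1Cc1ccc(F)c(Cl)c1`, gives 6870 nM in this assay. Compound 2 differs from compound 1 by chloro in place of fluoro on an aromatic carbon, a change that brought a 1.0-fold higher number from compound 1 to compound 2 (0.02 log units; within the scatter). Compound 3 differs from compound 2 by fluoro in place of hydrogen on an aromatic carbon, with a 1.3-fold lower number from compound 2 to compound 3 (0.12 log units; within the scatter). The difference between the cores of compound 1 and compound 3 is not broken down here. Compound 4, `O=C1c2c(ccc(O)c2O)CN1Cc1ccc(Cl)c(Cl)c1`, has not yet been measured; it differs from compound 3 by chloro in place of fluoro on an aromatic carbon. Among the compounds with values here, this is the same kind of change as the one from compound 1 to compound 2, but the surroundings differ: in compound 2 the chloro sits meta to a large group, whereas in compound 4 it sits ortho to a chloro group and para to a large group. The step is expected to be a 1.0-fold higher number from compound 3 to compound 4 (0.01 log units; within the scatter), close to the earlier one, because the same kind of change gave a 1.0-fold higher number from compound 1 to compound 2 (0.02 log units; within the scatter). Compound 4 is therefore expected to give about 7000 nM in this assay, most likely between 3500 nM and 14000 nM.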

Compound 4, half-maximal inhibitory concentration: 5680 nM
Compound 4: middle estimate off by 1.2-fold (0.09 log units), on the high side; low and high end bracket the measured number.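

In this assay, chloro in place of fluoro gave a 1.2-fold lower number from compound 3 to compound 4 (0.08 log units; within the scatter), and chloro in place of hydrogen gave a 1.6-fold lower number from compound 2 to compound 4 (0.20 log units; within the scatter). Set beside the earlier case, the chloro-for-fluoro change shows no measurable difference between the two cores: the same change on two cores in this assay, a 1.0-fold higher number (0.02 log units; within the scatter) from compound 1 to compound 2 and a 1.2-fold lower number (0.08 log units; within the scatter) from compound 3 to compound 4, 1.3-fold (0.10 log units) apart, within the scatter of two such steps. Within the data shown here, this shows that the change remained a small step within the scatter in both settings, where one chloro group sits in compound 4 and a different arrangement of groups surrounds the change in compound 2, but it does not show that the step has a fixed size, and with only two small steps a modest influence of the surroundings would stay hidden.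

On these data alone, all four compounds carry only fluoro or chloro groups on the aromatic ring that bears the change, so the effect of a methoxy group, a nitrile or an amine in that place remains open. As far as these compounds go, whether the same step would hold on a core lacking the two hydroxyl groups also remains open.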